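The compounds below may be only part of what the source reports. "The series", "measured", "known", "first", "only" and "open" are said of these compounds alone.

Compound 1 `C=CCSc1nnc(-c2cc(OC)c(OC)c(OC)c2)n1N1C(=O)c2ccccc2C1=O` gives in a functional assay on PC-3M cells (Homo sapiens) for cytotoxicity, read by MTT assay, with a stated time of 48 h (on this read-out higher numbers stand for weaker inhibition and lower numbers for stronger inhibition), only the limit > 200000 nM and no number.
Compound 2 `COc1cc(-c2nnc(SCc3ccccc3Cl)n2N2C(=O)c3ccccc3C2=O)cc(OC)c1OC` gives in this assay only the limit > 200000 nM.
Compound 3 `COc1cc(-c2nnc(SCc3ccccc3)n2N2C(=O)c3ccccc3C2=O)cc(OC)c1OC` gives in this assay only the limit > 200000 nM.

Compound 3 therefore stands at the same limit as every other measured member of the series, as the limit of > 200000 nM in this assay, at which 3 of the 3 values shown sit, records. Going by the values given here, the steps a step that the two limits leave unreadable from compound 1 to compound 3 and a step that the two limits leave unreadable from compound 2 to compound 3 are left unreadable by the two limits, and a step that the two limits leave unreadable from compound 1 to compound 2 likewise; no step in this set has a readable size. Among the compounds with values here, compound 4 `COc1cc(-c2nnc(SCC(=O)c3ccc(F)c(F)c3)n2N2C(=O)c3ccccc3C2=O)cc(OC)c1OC` introduces ((3,4-difluorophenyl)carbonyl in place of phenyl on a saturated chain carbon bound to a sulfur), a change no measured pair covers. With three limits and no readable step to build on, the expectation for compound 4 is a weak value, most likely another limit: estimate 150000 nM, range 30000 nM to 400000 nM, which would mean a step of an at least 1.3-fold lower number from compound 3 to compound 4 (0.12 log units; that floor lies within the scatter) from compound 3.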

Compound 4, half-maximal inhibitory concentration: 163000 nM
Estimate against measurement, compound 4: 1.1-fold (0.04 log units) below; the measured number falls inside the stated range.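

Compound 4 is the first member of the series to give a number rather than a limit in this assay, with (3,4-difluorophenyl)carbonyl on a saturated chain carbon bound to a sulfur; the other compounds share one mark: the limit of > 200000 nM in this assay, at which 3 of the 4 values shown sit.

The change reads as an at least 1.2-fold lower number from compound 3 to compound 4 (0.08 log units; that floor lies within the scatter), as an at least 1.2-fold lower number from compound 2 to compound 4 (0.08 log units; that floor lies within the scatter) and as an at least 1.2-fold lower number from compound 1 to compound 4 (0.08 log units; that floor lies within the scatter). Each is only a floor within the scatter, and none fixes a real size.

The compounds shown do not separate the carbonyl from the fluorines. Also open, from the compounds shown here alone, is whether phenylcarbonyl without fluorine, an amine or a carboxylic acid at this place gives a number at all.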